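What Compound 4 May Show After a Side-Chain Swap

The compounds below may be only part of what the source reports. "The series", "measured", "known", "first", "only" and "open" are said of these compounds alone.

In an in vivo ADME assay on the whole organism (blood) for pharmacokinetics, with Rattus norvegicus as the target (a lower number here means slower removal, a higher number faster removal of the compound), compound 2 `Cc1cc(C(=O)NCc2ccccn2)nn1Cc1cc(Cl)ccc1OCc1ccccc1` gives 68 mL/min/kg. Compound 3 `Cc1cc(NC(=O)C2CCCCC2)nn1Cc1cc(Cl)ccc1OCC(C)C` gives the same number at the digits shown, 68 mL/min/kg, while compound 1 `Cc1cc(C(=O)NCc2ccccc2)nn1Cc1cc(Cl)ccc1OCc1ccccc1` gives 75 mL/min/kg, within the scatter of compound 2. The three measured compounds therefore offer little spread to reason from.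

Compound 4 `Cc1cc(NC(=O)OC(C)(C)C)nn1Cc1cc(Cl)ccc1OCc1ccccc1` has not yet been measured. Its change from compound 2 is a large one: (tert-butoxycarbonyl)amino in place of ((pyridin-2-yl)methyl)carbamoyl on an aromatic carbon. The entering group has no ring, so a whole side chain is exchanged, not one part of it.

Among the compounds with values here, only one measured step touches the leaving group: a 1.1-fold lower number from compound 1 to compound 2 (0.04 log units; within the scatter). That step swaps phenyl for pyridin-2-yl and leaves the rest of the side chain in place, so it does not test the exchange in compound 4. As in compound 4, the carbonyl of compound 3 reaches the shared core through a nitrogen, and compound 3 gives 68 mL/min/kg, though it differs elsewhere too.

No step beyond the scatter is therefore expected, and the estimated step is a 1.1-fold lower number from compound 2 to compound 4 (0.05 log units; within the scatter). With no direct test of this exchange, the expected range stays wide. For compound 4 the estimate is 60 mL/min/kg, with an expected range from 30 mL/min/kg to 95 mL/min/kg.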

Compound 4, clearance: 42 mL/min/kg
The estimate for compound 4 lay 1.4-fold (0.15 log units) above the measured number, and the stated range covers the measured number.
By their numbers in this assay, from the lowest: compounds 4, 2, 3 and 1 (each within the scatter of the next).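

In this assay, exchanging the whole side chain on this aromatic carbon, ring included, gives a 1.6-fold lower number from compound 2 to compound 4 (0.21 log units; within the scatter), and the same exchange starting from benzylcarbamoyl gives a 1.8-fold lower number from compound 1 to compound 4 (0.25 log units; within the scatter). The earlier pair of compound 1 and compound 2 changed only the ring at the end of the side chain, whereas these two steps remove that ring altogether, and neither step lies beyond the scatter. At this position, then, a side chain with no ring and side chains carrying a six-membered aromatic ring cannot be told apart by this measurement, and no measured evidence is available that would explain the numbers.

From the compounds shown here alone, it remains open whether a group of a different kind on this aromatic carbon, such as a primary amine or a carboxylic acid, would produce a step beyond the scatter. Going by these compounds, it is also open whether (tert-butoxycarbonyl)amino would give a similar reading if the benzyl ether of compound 4 were replaced by the branched ether chain of compound 3, as no single-place comparison here tests that pairing.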